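The source may hold more compounds than are shown below. What is called first, only, known or untested is meant among the compounds shown, and "the series" means these compounds.

Two compounds have so far been measured in a functional assay on RPMI-8226 cells (Homo sapiens) for inhibition, read by sulforhodamine B assay, with a stated time of 48 h, tested at 10 uM; on this read-out higher numbers stand for more inhibition of growth at the one concentration tested and lower numbers for less inhibition of growth:

Compound 1, `C/C(=N\O)c1ccc(NC(=O)Cn2nc(-c3ccc(Cl)cc3)nc2N)cc1`: 6.42%
Compound 2, `c1ccc(-c2nc3sc(-c4ccccc4)cn3n2)cc1`: 14%

On these two numbers compound 1 stands lowest. Among the measured compounds shown here, its only neighbour is compound 2, whose value lies higher by an amount that stays within the usual scatter of this read-out, so the two values cannot be told apart. For the measured compounds named here, compound 2 shares no core with compound 1, and no step between measured compounds that differ in a single place has been recorded.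

The compound still to be measured is compound 3, `CC(=O)c1ccc(NC(=O)Cn2nc(-c3ccc(Cl)cc3)nc2N)cc1`. It differs from compound 1 in one place: a group of 3 heavy atoms (2 carbon, 1 oxygen; no ring) in place of a group of 4 heavy atoms (2 carbon, 1 nitrogen, 1 oxygen; no ring), on an aromatic carbon

Going by the values given here, no measured pair shows what such an exchange does here, and compound 2 is too far removed in structure to serve as a guide. Given that compound 1 sits near the bottom of the scale with 6.42%, and that the exchange touches only a small part of the molecule, the step is expected to be small and not clearly beyond the scatter in either direction: a number 1.6 percentage points higher from compound 1 to compound 3 (within the scatter). Compound 3 is therefore expected to give about 8% in this assay, within a range from -4% to 22%.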

Compound 3, percent growth inhibition at one concentration: 3.17%
Compound 3: the middle estimate sits 4.8 percentage points above what was measured, and the stated range covers the measured number.
By their numbers in this assay, from the lowest: compounds 3, 1 and 2 (each within the scatter of the next, the first and the last beyond it).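

Among the compounds shown here, the one step now available at this position, on an aromatic carbon para to a large group, exchanges the group of compound 1 for acetyl, and in this assay it gives a number 3.3 percentage points lower from compound 1 to compound 3 (within the scatter). The exchange takes the count from 1 hydrogen-bond donor and 2 hydrogen-bond acceptors in the leaving group to 0 hydrogen-bond donors and 1 hydrogen-bond acceptor in acetyl, yet compound 1 at 6.42% and compound 3 at 3.17% cannot be told apart, so this change at this position leaves the read-out unmoved beyond the usual scatter. No measurement at hand bears on this result or offers an account of it.

Going by these compounds, whether a group of another kind on this aromatic carbon, such as an amine, a carboxylic acid or a longer chain, would move the number clear of the scatter remains open. With a single exchange on the shared core, read at one concentration, the compounds shown also leave open whether changes elsewhere on the core of compound 1 would matter more than this one.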